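The source may report more compounds than this note shows. Statements on the series, on what has been measured and on what is new or still open speak of the compounds shown alone.

Compound 1 `CCCCCSCCC1C2CCC(O2)C1C/C=C\CCCC(=O)O` is a thromboxane receptor ligand of modest strength: in a functional assay on a cell-free system (plasma) with thromboxane A2 receptor (Homo sapiens) as the target (a higher number here means a weaker inhibitor, a lower number a stronger inhibitor), compound 1 gives 37000 nM. Among the three measured compounds it holds the second highest number. Its nearest neighbour is compound 2 `O=C(O)CCC/C=C\CC1C2CCC(O2)C1CSCC1CCCCC1`, which in this assay gives 20000 nM; the step of a 1.9-fold lower number from compound 1 to compound 2 (0.27 log units; within the scatter) stays within the scatter, so the two cannot be ranked. Compound 3 `O=C(O)CCC/C=C\CC1C2CCC(O2)C1CSC/C=C/c1ccccc1` gives 86000 nM in this assay, a higher number than compound 1, and the step of a 4.3-fold higher number from compound 2 to compound 3 (0.63 log units; beyond the scatter) shows that swapping the saturated ring on the sulfur-bearing arm for an unsaturated aromatic one weakens inhibition modestly.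

Compound 4 `CCCNC(=O)CSCC1C2CCC(O2)C1C/C=C\CCCC(=O)O` has not yet been measured. It differs from compound 1 by a group of 8 heavy atoms (5 carbon, 1 nitrogen, 1 oxygen, 1 sulfur; no ring) in place of a group of 7 heavy atoms (6 carbon, 1 sulfur; no ring), on a saturated chain carbon bound to a saturated ring carbon. Both measured steps touch the same sulfur-bearing arm, but neither introduces an amide or a hydrogen-bond donor, so their bearing is indirect: the within-scatter step from compound 1 to compound 2 suggests the arm tolerates reshaping, while the modest step from compound 2 to compound 3 shows that not every change there is neutral. The expectation for compound 4 is therefore a number close to that of compound 1, with the step of a 1.1-fold higher number from compound 1 to compound 4 (0.03 log units; within the scatter) expected to fall within the scatter. Compound 4 is estimated to give 40000 nM in this assay, with a range from 10000 nM to 150000 nM.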

Compound 4, half-maximal inhibitory concentration: 72000 nM
The estimate for compound 4 lay 1.8-fold (0.26 log units) below the measured number, within the range that was stated.
By their numbers in this assay, from the lowest: compounds 2, 1, 4 and 3 (each within the scatter of the next, the first and the last beyond it).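

Within the data shown here, the amide-bearing group is the first in this set to carry a hydrogen-bond donor on this saturated chain carbon bound to a saturated ring carbon, yet this assay cannot separate it from the group it replaces: a 1.9-fold higher number from compound 1 to compound 4 (0.29 log units; within the scatter) leaves the two unranked. Propylcarbamoyl and 2-phenylethenyl, on a saturated chain carbon bound to a sulfur, cannot be ranked either, with a 1.2-fold lower number from compound 3 to compound 4 (0.08 log units; within the scatter) as their step, while the comparison with cyclohexyl does exceed the scatter, with a 3.6-fold higher number from compound 2 to compound 4 (0.56 log units; beyond the scatter) as a modest change. Thus, among the groups compared directly on that carbon, only cyclohexyl separates from the others, and no measurement offered here accounts for that difference.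

The compounds shown leave open whether the hydrogen-bond donor matters at all, which a tertiary amide with no amide hydrogen on the same arm would test. They also leave open how a longer chain on the amide nitrogen, a cyclohexyl group there in place of propyl, or a primary amine at the end of the arm would read in this assay against the numbers already in hand.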